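Dropping an Ethoxy Group and Watching Inhibition Shift

This account rests on a few compounds, and the source may have more. Where it says the series, first, only, none or still open, it means among the compounds named here.

Among the measured compounds shown here, compound 2 `CCOc1c(OC)cc(/C=C/C(=O)c2ccncc2)cc1OC` gives 230 nM in an assay on cell membranes for inhibition of cytochrome P450 1A1 (Homo sapiens), read by fluorescence, using microsomes, with a stated time of 10 min (on this read-out lower numbers stand for stronger inhibition and higher numbers for weaker inhibition), the lowest of the two numbers measured so far. Compound 1 `COc1cccc(/C=C/C(=O)c2ccncc2)c1` gives 590 nM in this assay, a gap wider than repeated measurements usually show. Compound 3 `COc1cc(/C=C/C(=O)c2ccncc2)cc(OC)c1` is still unmeasured. Compared with compound 2, the change is hydrogen in place of ethoxy on an aromatic carbon. For the measured compounds named here, no measured pair isolates this change, so the expectation rests only on the two values shown, with compound 3 placed between them. A modest weakening is expected, as the step of a 1.7-fold higher number from compound 2 to compound 3 (0.24 log units; within the scatter). For compound 3 the estimated value is 400 nM, within 150 nM to 1000 nM.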

Compound 3, half-maximal inhibitory concentration: 180 nM
Compound 3: middle estimate off by 2.2-fold (0.35 log units), on the high side, within the range that was stated.
By their numbers in this assay, from the lowest: compounds 3 and 2 (each within the scatter of the next); then compound 1.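

Hydrogen in place of ethoxy on this aromatic carbon gives a 1.3-fold lower number from compound 2 to compound 3 (0.11 log units; within the scatter) in this assay, so inhibition at this level does not depend on the ethoxy group. The clearer difference lies elsewhere: methoxy in place of hydrogen on an aromatic carbon gives a 3.3-fold lower number from compound 1 to compound 3 (0.52 log units; beyond the scatter) in this assay, a modest step beyond the scatter. Among the compounds shown here, of these two single changes, only the one linking compound 1 and compound 3 separates the values.

An amine or a longer chain such as butoxy on the carbon that carries ethoxy in compound 2 remains untested among the compounds shown. Nothing available explains why either step has the size it does.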